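Notes on a small antiproliferative series: nitro to chloro

This account rests on a few compounds, and the source may have more. Where it says the series, first, only, none or still open, it means among the compounds named here.

Measured so far:
compound 1 `O=Cc1cn(-c2ccccc2)nc1-c1ccc([N+](=O)[O-])cc1` — 97%
compound 2 `O=Cc1cn(-c2ccccc2)nc1-c1cccc([N+](=O)[O-])c1` — 89%

In a functional assay on MCF7 cells (Homo sapiens) for antiproliferative activity, read by MTT assay, with a stated time of 24 h, tested at 0.001 ug/mL (on this read-out lower numbers stand for a stronger effect and higher numbers for a weaker effect at the one concentration tested), compound 1 gives 97%. Compound 2, which carries its nitro group at a different position of the same aromatic ring, gives 89% in this assay. Compound 1 sits at the upper edge of the two numbers, but the gap to compound 2 lies within the usual scatter of repeated measurements, so the two cannot be told apart. Both read-outs sit close to the weak end of the scale at the single concentration tested: neither compound shows much effect on cell growth in this assay under these conditions.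

Compound 3 `O=Cc1cn(-c2ccccc2)nc1-c1ccc(Cl)cc1` has not yet been measured. It differs from compound 1 by chloro in place of nitro on an aromatic carbon. For the measured compounds named here, no step between measured compounds is available to calibrate this change, and the two measured values give no sign of a trend to extend. The expectation is therefore a step of no size beyond the scatter in this assay, in either direction. Compound 3 is expected to give about 93% in this assay, within a range of 80% to 104%. The expected step of a number 4 percentage points lower from compound 1 to compound 3 (within the scatter) lies within the scatter.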

Compound 3, a percentage reported as activity, at one concentration (the size of the read-out at that concentration, not a potency): 98%
Estimate against measurement, compound 3: 5 percentage points below; the range from low to high includes it.
By their numbers in this assay, from the lowest: compounds 2, 1 and 3 (each within the scatter of the next).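

Chloro in place of nitro, on an aromatic carbon para to a large group, gives in this assay a number 1 percentage points higher from compound 1 to compound 3 (within the scatter), so exchanging nitro for the single heavy atom of chloro, with no hydrogen-bond acceptors left at this place, leaves the read-out unresolved from that of the parent. For the compounds shown here, the earlier pair only varied where the nitro group sat on the ring, whereas this result is the first reading of a different group at this place, and compound 3 , at 98%, stays close to the weak end of the scale at the single concentration tested. Nothing available on the compounds or their groups bears on this result.

From the compounds shown here alone, it remains open whether an amine or a carboxylic acid at this place would move the read-out beyond the scatter, or whether it stays as flat as it does with nitro and chloro. Also open, going by these compounds, is whether compound 1 and compound 3 would separate at a higher concentration, where more of the scale could come into play.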